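A Second Chloro on Compound 3

The source may report more compounds than this note shows. Statements on the series, on what has been measured and on what is new or still open speak of the compounds shown alone.

In a functional assay on MCF7 cells (Homo sapiens) for antiproliferative activity, read by MTT assay, with a stated time of 72 h (on this read-out higher numbers stand for weaker inhibition and lower numbers for stronger inhibition), compound 3 `COc1cc(-n2cnc3ccc(-c4ccc(Cl)cc4)cc32)cc(OC)c1OC` gives 1320 nM. Compound 1 `COc1cc(-n2cnc3ccc(-c4ccc([N+](=O)[O-])cc4)cc32)cc(OC)c1OC` gives 740 nM, and compound 2 `COc1cc(-n2cnc3ccc(-c4cccc(C)c4)cc32)cc(OC)c1OC` gives 360 nM. Compound 4 `COc1cc(-n2cnc3ccc(-c4ccc(Cl)cc4Cl)cc32)cc(OC)c1OC` turns 4-chlorophenyl into 2,4-dichlorophenyl, with chloro in place of hydrogen on an aromatic carbon, ortho to a large group: chloro in place of hydrogen on an aromatic carbon. Among the compounds with values here, no measured step makes this change directly. The nearest guides are exchanges on the same ring, namely a 1.8-fold higher number from compound 1 to compound 3 (0.25 log units; within the scatter), and a 3.7-fold higher number from compound 2 to compound 3 (0.56 log units; beyond the scatter), the latter only modest. A small move is therefore expected, with no clear direction. The expected step is a 1.1-fold higher number from compound 3 to compound 4 (0.06 log units; within the scatter), which should stay within the scatter. For compound 4 the estimated value is 1500 nM, with an expected range from 500 nM to 4000 nM.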

Compound 4, half-maximal inhibitory concentration: 5420 nM
The estimate for compound 4 lay 3.6-fold (0.56 log units) below the measured number; measured number above the stated range.
By their numbers in this assay, from the lowest: compound 2; then compounds 1 and 3 (each within the scatter of the next); then compound 4.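

Among the compounds shown, only this step adds a group to the ring rather than exchanging one, and in this assay chloro in place of hydrogen, ortho to a large group, weakens inhibition (a 4.1-fold higher number from compound 3 to compound 4 (0.61 log units; beyond the scatter)). It also separates the 2,4-dichlorophenyl compound from both others (a 7.3-fold higher number from compound 1 to compound 4 (0.86 log units; beyond the scatter); a 15-fold higher number from compound 2 to compound 4 (1.18 log units; beyond the scatter)), the second step being large. Nothing measured here accounts for this loss.

Going by these compounds, it remains open whether fluoro or an amine at this place would raise the number as chloro does. On these data alone, whether chloro here would have the same effect without the chloro already present in compound 3 also remains open.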